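Compound 3 to Compound 4: One Fluorine Fewer

The source may hold more compounds than are shown below. What is called first, only, known or untested is meant among the compounds shown, and "the series" means these compounds.

Compound 3 `CC(C)n1ncc2c(C(=O)Nc3ccc(F)c(F)c3)cc(-c3cccs3)nc21` was measured in an ADME assay on LLC-MK2 cells (Macaca mulatta) for cytotoxicity, read by spectrophotometry and crystal violet staining, with a stated time of 4 days; on this read-out higher numbers stand for lower toxicity in this test and lower numbers for higher toxicity in this test. There compound 3 reaches only a limit, > 200000 nM. Compound 2 `CC(C)n1ncc2c(C(=O)Nc3ccc(F)cc3)cc(-c3cccs3)nc21` likewise reaches only a limit in this assay, > 200000 nM. Compound 1 `CC(C)n1ncc2c(C(=O)Nc3ccncc3)cc(-c3cccs3)nc21`, different at the amide-type nitrogen, gives 6300 nM in this assay. The steps of an at least 31-fold higher number from compound 1 to compound 2 (1.50 log units; beyond the scatter) and an at least 31-fold higher number from compound 1 to compound 3 (1.50 log units; beyond the scatter) are both large, whereas a step that the two limits leave unreadable from compound 2 to compound 3, a consequence of the limit of > 200000 nM in this assay, at which 2 of the 3 values shown sit. Compound 4 `CC(C)n1ncc2c(C(=O)Nc3ccccc3F)cc(-c3cccs3)nc21` carries 2-fluorophenyl in place of 3,4-difluorophenyl on an amide-type nitrogen. Given the steps of an at least 31-fold higher number from compound 1 to compound 2 (1.50 log units; beyond the scatter) and an at least 31-fold higher number from compound 1 to compound 3 (1.50 log units; beyond the scatter), compound 4 is expected to remain at the limit, so the expected step of a number no higher from compound 3 to compound 4 (the limit leaves the size open) cannot be read. Compound 4 is thus estimated at 200000 nM in this assay, between 60000 nM and 500000 nM.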

Compound 4, half-maximal cytotoxic concentration: 50000 nM
Compound 4: middle estimate off by 4.0-fold (0.60 log units), on the high side, and the stated range ends above it.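

In this assay, moving to 2-fluorophenyl on the amide-type nitrogen gives an at least 4.0-fold lower number from compound 3 to compound 4 (0.60 log units; beyond the scatter) and an at least 4.0-fold lower number from compound 2 to compound 4 (0.60 log units; beyond the scatter), so at this position the fluorophenyl groups shown do not all behave alike. The same group still gives a 7.9-fold higher number from compound 1 to compound 4 (0.90 log units; beyond the scatter), which keeps compound 4 on the higher side of the pyridin-4-yl compound. The size of the first two steps stays open because compound 2 and compound 3 are limits: the limit of > 200000 nM in this assay, at which 2 of the 4 values shown sit.

The compounds shown leave open whether a chlorophenyl or a methoxyphenyl group on this nitrogen would reach the limit or resemble compound 4.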